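The compounds below may be only part of what the source reports. "The series", "measured", "known", "first", "only" and "open" are said of these compounds alone.

In a physicochemical assay for lipophilicity (on this read-out lower numbers stand for lower lipophilicity and higher numbers for higher lipophilicity), compound 1 (`CCCCS(=O)(=O)c1ccc(O)c(C(=O)Nc2ccc(C(F)(F)F)cc2)c1`) gives 3.1 as its reading. Among the measured compounds shown here, compound 2 (`CCCCCCS(=O)(=O)c1ccc(O)c(C(=O)Nc2ccc(C(F)(F)F)cc2)c1`) gives 4.18 and so stands highest of the two numbers so far. Compound 3 (`CS(=O)(=O)c1ccc(O)c(C(=O)Nc2ccc(C(F)(F)F)cc2)c1`) is still unmeasured. It differs from compound 2 by trading hexyl for methyl, which is hydrogen in place of pentyl on a saturated chain carbon bound to a sulfonyl sulfur. For the measured compounds named here, only one measured step bears on this change: a number 1.08 log units higher from compound 1 to compound 2 (beyond the scatter) came with ethyl in place of hydrogen on the same chain. Here more chain leaves than was added in that step, so a larger move downward is expected, though a single step cannot show that the trend holds evenly all the way to methyl. The estimate is a number 2.58 log units lower from compound 2 to compound 3 (beyond the scatter) as the expected step. For compound 3 the estimated value is 1.6 with an expected range from 1 to 2.3 on this scale.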

Compound 3, distribution coefficient: 1.48
Compound 3: the middle estimate sits 0.12 log units above what was measured, and the stated range covers the measured number.
By their numbers in this assay, from the lowest: compound 3; then compound 1; then compound 2.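

Compound 3 extends the series down to methyl, and in this assay the reading keeps falling as the chain on the sulfonyl sulfur shortens: a number 2.70 log units lower from compound 2 to compound 3 (beyond the scatter) and a number 1.62 log units lower from compound 1 to compound 3 (beyond the scatter) are both large. The earlier pair could show only a single rise, whereas these steps stay in proportion to the length of chain exchanged, so methyl, butyl and hexyl fall on one even trend, with none of the three going against it. Nothing measured here explains that evenness.

Three chain lengths cannot show whether a longer chain than hexyl would stay on the same trend. Also open, as far as these compounds go, is how a branched chain, an amine or a carboxylic acid would read on a saturated chain carbon bound to a sulfonyl sulfur.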